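The compounds below may be only part of what the source reports. "The series", "measured", "known", "first", "only" and "open" are said of these compounds alone.

Measured so far:
- compound 1 `Cc1ccc(NC(=O)N[C@@H](C)c2ccccc2)cc1`: 100%
- compound 2 `CCCCc1ccc(NC(=O)N[C@H](C)c2ccccc2)cc1`: 28%

Both were tested in an ADME assay on the whole organism with Oryza sativa as the target, tested at 10 uM; a lower number here means a stronger effect, a higher number a weaker effect of the compound at the concentration tested. Compound 2 gives the lower of the two numbers in this assay, and compound 1 sits far higher, beyond the usual scatter. Compound 3 `CCCCc1ccc(NC(=O)N[C@@H](C)c2ccccc2)cc1` has not been measured yet. It differs from compound 2 only in this way: the two compounds have the same atoms and bonds and differ only in configuration as drawn: 1 of 1 stereo elements differ; a stereocentre at a saturated chain carbon is drawn R in compound 2 and S in compound 3. Going by the values given here, no measured pair in this set differs only by configuration, so the size and direction of this step is unknown. Compound 3 is expected to read somewhere between the two measured numbers, so a step of a number 17 percentage points higher from compound 2 to compound 3 (beyond the scatter) is estimated, with compound 3 expected at about 45%, in the range 15% to 90%.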

Compound 3, a percentage reported as activity, at one concentration (the size of the read-out at that concentration, not a potency): 60%
For compound 3 the middle estimate is 15 percentage points below the measured one, within the range that was stated.
By their numbers in this assay, from the lowest: compound 2; then compound 3; then compound 1.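

Inverting the stereocentre at the saturated chain carbon gives a number 32 percentage points higher from compound 2 to compound 3 (beyond the scatter) in this assay, and this step can be traced to configuration alone because the structures are otherwise identical: the fact that compounds 2 and 3 differ only in the configuration as drawn. With the S configuration kept, propyl in place of hydrogen gives a number 40 percentage points lower from compound 1 to compound 3 (beyond the scatter), so the chain change also shifts the number on its own. The R form therefore reads lower here, though this rests on a single pair.

Going by these compounds, it remains open whether a longer chain or an amine at this place would lower the number further. On these data alone, it is also open whether the R form would still read lower with those groups.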